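Chlorophenyl for Methylphenyl on the Triazole Nitrogen

A few compounds are considered here, and "the series" means these few. Any claim that something is new, unique, unknown or untested is made for them only; others in the source may bear on it.

Compound 1 `COc1ccccc1-n1nncc1CN1C(=O)C2(C(C#N)=C(N)Oc3c2c2nc4ccccc4nc2c2ccccc32)c2ccccc21` and compound 2 `Cc1cccc(-n2nncc2CN2C(=O)C3(C(C#N)=C(N)Oc4c(N)cc5nc6ccccc6nc5c43)c3ccccc32)c1` share a spirocyclic core and were both tested in an ADME assay on HUVEC cells (Homo sapiens) for antiproliferative activity, read by MTT assay, with a stated time of 48 h; on this read-out higher numbers stand for weaker inhibition and lower numbers for stronger inhibition. Compound 1 gives no number there, only the limit of > 50000 nM. Compound 2 likewise reaches only the limit of > 50000 nM. Going by the values given here, compound 2 therefore stands at the limit, as does the one further value shown, which is summed up by the limit of > 50000 nM in this assay, at which 2 of the 2 values shown sit. Among the compounds with values here, no measured pair differs in one place, so no measured step is available. Compound 3 `N#CC1=C(N)Oc2c(N)cc3nc4ccccc4nc3c2C12C(=O)N(Cc1cnnn1-c1ccc(Cl)cc1)c1ccccc12` is not yet measured; it departs from compound 2 by 4-chlorophenyl in place of 3-methylphenyl on an aromatic nitrogen, in words 4-chlorophenyl in place of 3-methylphenyl on an aromatic nitrogen. Since both values seen in this assay are limits, the expected step that the limit leaves unreadable from compound 2 to compound 3 is none beyond the scatter, and compound 3 is expected to remain at the limit. Compound 3 is estimated at 70000 nM, with a range from 30000 nM to 200000 nM.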

Compound 3, half-maximal inhibitory concentration: > 50000 nM
Compound 3 ended at the assay's limit; the forecaster's own chance of this, stated with the estimate: 85%; the middle value does not contradict the limit.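

Going by these compounds alone, compound 2 and compound 3 both stand only at a limit in this assay, so no step between them can be read. The compounds shown leave open how 4-chlorophenyl and 3-methylphenyl compare, and which change would bring any compound within measurable range: the limit of > 50000 nM in this assay, at which 3 of the 3 values shown sit.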